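Thiazolylmethyl for methylpyrrolylmethyl on the amide nitrogen

A few compounds are considered here, and "the series" means these few. Any claim that something is new, unique, unknown or untested is made for them only; others in the source may bear on it.

Compound 1 `CCN(Cc1cccn1C)C(=O)COc1ccc(C)cc1` gives 21300 nM in an assay on HEK293 cells for agonist activity at transient receptor potential cation channel subfamily M member 8 (Homo sapiens), read by fluorescence and calcium flux, with a stated time of 15 min (on this read-out lower numbers stand for an effect already at smaller amounts and higher numbers for an effect only at larger amounts of compound), the highest of the three numbers; compound 2 `Cc1ccc(OCC(=O)N(Cc2cccs2)CC(C)C)cc1` gives 900 nM and compound 3 `Cc1ccc(OCC(=O)N(Cc2cccs2)c2ncco2)cc1` gives 0.3 nM. Within the data shown here, the only single-point step, a 3000-fold lower number from compound 2 to compound 3 (3.48 log units; beyond the scatter), changes the other substituent on the amide-type nitrogen, not the ring on the saturated chain carbon, so it does not bear on the change to compound 4 `CCN(Cc1cncs1)C(=O)COc1ccc(C)cc1`: 1,3-thiazol-5-yl in place of 1-methyl-1H-pyrrol-2-yl on a saturated chain carbon bound to an amide-type nitrogen. Compounds 1 and 2 differ in two places, so their values alone say nothing about the ring. Among the measured compounds shown here, with no step of this kind measured, the expected step of a 1.4-fold lower number from compound 1 to compound 4 (0.15 log units; within the scatter) is none beyond the scatter. Compound 4 is therefore estimated at 15000 nM, within 4000 nM to 60000 nM.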

Compound 4, half-maximal effective concentration: 1100 nM
The estimate for compound 4 lay 14-fold (1.13 log units) above the measured number; measured number below the stated range.
By their numbers in this assay, from the lowest: compound 3; then compounds 2 and 4 (each within the scatter of the next); then compound 1.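

With ethyl held constant on the amide-type nitrogen, the ring on the saturated chain carbon also moves the read-out in this assay: the change gives a 19-fold lower number from compound 1 to compound 4 (1.29 log units; beyond the scatter). Until now, a single-place step had been seen only for the other substituent on that nitrogen. The step cannot separate the change in ring hetero atoms from the loss of the N-methyl carbon, and nothing at hand accounts for it.

Open, from the compounds shown here alone, is whether the change carries over with isobutyl or 1,3-oxazol-2-yl as the other substituent. Also open, going by these compounds, is how a phenyl or pyridin-3-yl ring would read in this place.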